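Compound 1 to compound 3: acetyl to dimethylcarbamoyl

The source may report more compounds than this note shows. Statements on the series, on what has been measured and on what is new or still open speak of the compounds shown alone.

Measured in an ADME assay on J774 cells (Mus musculus) for cytotoxicity; on this read-out lower numbers stand for an effect already at smaller amounts and higher numbers for an effect only at larger amounts of compound:
- compound 1 `CCCCc1cc2c(=O)c(C(C)=O)c[nH]c2cc1OCCOc1ccccc1`: "not determined" (no result reported)
- compound 2 `COC(=O)c1c[nH]c2cc(OCCOc3ccccc3)c(Br)cc2c1=O`: > 20000 nM

Compound 1 has no number to stand on in this assay, since compound 1 reads "not determined" (no result reported). The only figure nearby belongs to compound 2, which gives > 20000 nM, and this is a limit of the assay and not a number. The next compound, compound 3 `CCCCc1cc2c(=O)c(C(=O)N(C)C)c[nH]c2cc1OCCOc1ccccc1`, has yet to be measured in this assay. Its change puts dimethylamino in place of methyl on a carbonyl carbon, taking acetyl to dimethylcarbamoyl (dimethylamino in place of methyl on a carbonyl carbon). Within the data shown here, no measured step covers this change, so its size cannot be read from the data. In this assay, a shift beyond the usual scatter is not expected in either direction. The expected value for compound 3 is 15000 nM, with an estimated range of 5000 nM to 40000 nM.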

Compound 3, half-maximal effective concentration: 15300 nM
Estimate against measurement, compound 3: 1.0-fold (0.01 log units) below; the range from low to high includes it.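

No step can be read from compound 1 to compound 3 in this assay: compound 3 gives 15300 nM, while compound 1 gives "not determined" (no result reported). The compounds shown leave open what acetyl to dimethylcarbamoyl does to this read-out, and one value shown is only a limit: the limit of > 20000 nM in this assay, at which 1 of the 3 values shown sits.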